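Changing the aryl group on the hydrazone of compound 2

This account rests on a few compounds, and the source may have more. Where it says the series, first, only, none or still open, it means among the compounds named here.

Measured so far:
compound 1 `O=C(CSc1nnc(-c2ccncc2)o1)N/N=C/c1ccc(Br)cc1`: 24500 nM
compound 2 `COc1ccc(/C=N/NC(=O)CSc2nnc(-c3ccncc3)o2)cc1`: 19800 nM

In a functional assay on BGC-823 cells (Homo sapiens) for cytotoxicity, read by MTT assay, with a stated time of 48 h (on this read-out higher numbers stand for weaker inhibition and lower numbers for stronger inhibition), compound 1 gives 24500 nM and compound 2 gives 19800 nM. Of these two numbers, compound 2 holds the one at the bottom, yet the gap to compound 1 is within the scatter, so the two compounds cannot be told apart on this read-out. Compound 3 `O=C(CSc1nnc(-c2ccncc2)o1)N/N=C/c1ccccc1[N+](=O)[O-]` differs from compound 2 in one place: 2-nitrophenyl in place of 4-methoxyphenyl on a carbon with a double bond to nitrogen. Within the data shown here, the only measured step, a 1.2-fold lower number from compound 1 to compound 2 (0.09 log units; within the scatter), also swapped a group on that same aromatic ring and stayed within the scatter, so it bears on this change but offers no direct precedent for a nitro group or for a substituent in a different position. On that basis no step beyond the scatter is expected for compound 3, and the expected step is a 1.1-fold higher number from compound 2 to compound 3 (0.03 log units; within the scatter). The estimate for compound 3 is 21000 nM, with a range from 8000 nM to 55000 nM.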

Compound 3, half-maximal inhibitory concentration: 41600 nM
For compound 3 the middle estimate is 2.0-fold (0.30 log units) below the measured one; measured number inside the range.
By their numbers in this assay, from the lowest: compounds 2, 1 and 3 (each within the scatter of the next, the first and the last beyond it).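

Among these compounds, the aryl group on the carbon with a double bond to nitrogen can move the result in this assay beyond the scatter: 2-nitrophenyl in place of 4-methoxyphenyl gives a 2.1-fold higher number from compound 2 to compound 3 (0.32 log units; beyond the scatter) and is the first step to do so, though only modestly. The same group in place of 4-bromophenyl gives a 1.7-fold higher number from compound 1 to compound 3 (0.23 log units; within the scatter) and so sets compound 3 apart from compound 2 but not from compound 1. No measurement at hand gives a reason for the step.

In 2-nitrophenyl both the group and where it sits on the ring differ from the earlier compounds, and the compounds shown do not separate these two changes. On these data alone, how an amine or a carboxylic acid on this ring would read also stays open.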